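This account rests on a few compounds, and the source may have more. Where it says the series, first, only, none or still open, it means among the compounds named here.

Measured in a functional assay on CNE-2 cells (Homo sapiens) for antiproliferative activity, read by sulforhodamine B assay, with a stated time of 48 h; on this read-out higher numbers stand for weaker inhibition and lower numbers for stronger inhibition:
- compound 1 `COc1ccc(C(=O)/C=C/c2ccccc2-c2ccc(F)cc2)cc1`: 9000 nM
- compound 2 `COc1ccc(C(=O)/C=C/c2ccccc2-c2ccc(F)nc2)cc1`: 13000 nM
- compound 3 `O=C(/C=C/c1ccccc1-c1ccc(F)cc1)c1cccc(O)c1`: 7300 nM

Compound 3, at 7300 nM, lies within the scatter of both compound 1 and compound 2, so this assay gives no order among the three.

The next compound is compound 4 `O=C(/C=C/c1ccccc1-c1ccc(F)nc1)c1cccc(O)c1`, not yet measured. It carries 6-fluoropyridin-3-yl in place of the 4-fluorophenyl of compound 3, on an aromatic carbon of a six-membered aromatic ring of carbon only, ortho to a large group: 6-fluoropyridin-3-yl in place of 4-fluorophenyl on an aromatic carbon.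

The same exchange has been measured once, on the 4-methoxyphenyl ketone side of the series: a 1.4-fold higher number from compound 1 to compound 2 (0.16 log units; within the scatter). The other measured step, 3-hydroxyphenyl in place of 4-methoxyphenyl, links compound 1 to compound 3 and is also small: a 1.2-fold lower number from compound 1 to compound 3 (0.09 log units; within the scatter). Compound 4 combines these two changes, and neither moved the number beyond the scatter. Going by these compounds, this rests on a single pair for the exchange itself, so its transfer to the 3-hydroxyphenyl compounds is untested. No step beyond the scatter is therefore expected in this assay. The expected step, taken from the size of the step to compound 2, is a 1.4-fold higher number from compound 3 to compound 4 (0.16 log units; within the scatter).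

For compound 4 the estimated value is 10500 nM, with an expected range of 5500 nM to 20000 nM.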

Compound 4, half-maximal inhibitory concentration: 8700 nM
The estimate for compound 4 lay 1.2-fold (0.08 log units) above the measured number; low and high end bracket the measured number.
By their numbers in this assay, from the lowest: compounds 3, 4, 1 and 2 (each within the scatter of the next).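

In this assay the exchange of 4-fluorophenyl for 6-fluoropyridin-3-yl, on the aromatic carbon ortho to a large group, now has a reading on a second core, a 1.2-fold higher number from compound 3 to compound 4 (0.08 log units; within the scatter), and the two readings agree: the same change on two cores in this assay, a 1.4-fold higher number (0.16 log units; within the scatter) from compound 1 to compound 2 and a 1.2-fold higher number (0.08 log units; within the scatter) from compound 3 to compound 4, 1.2-fold (0.08 log units) apart, within the scatter of two such steps

The exchange of 4-methoxyphenyl for 3-hydroxyphenyl on the carbonyl carbon also gains a second reading, a 1.5-fold lower number from compound 2 to compound 4 (0.17 log units; within the scatter), with the same agreement: the same change on two cores in this assay, a 1.2-fold lower number (0.09 log units; within the scatter) from compound 1 to compound 3 and a 1.5-fold lower number (0.17 log units; within the scatter) from compound 2 to compound 4, 1.2-fold (0.08 log units) apart, within the scatter of two such steps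

The four compounds thus close a square in which neither change moves the number beyond the scatter on either core, and the two changes show no sign of depending on each other, so the hydrogen-bond acceptor that enters with 6-fluoropyridin-3-yl leaves the number within the scatter in both settings.

Still open, going by these compounds, is whether any group at this position can move the number beyond the scatter, since both groups compared here are fluorine-bearing six-membered aromatic rings, and a carboxylic acid or an aminomethyl group in their place would be a wider test. Also open, on these data alone, is how the ring on the carbonyl carbon responds to an amine or a longer alkoxy chain.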